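Aryl amide swap at the anilide end of the series

The compounds below may be only part of what the source reports. "The series", "measured", "known", "first", "only" and "open" are said of these compounds alone.

Measured so far:
compound 1, `Cc1coc2cc(OCC(=O)Nc3cccc(NC(=O)c4ccc(N(C)C)cc4)c3)ccc2c1=O`, 2150 nM in an assay on isolated protein for inhibition of Rho-associated protein kinase 2 (Homo sapiens), read by scintillation counting, radiometric assay and 33P incorporation, with a stated time of 40 min, in the presence of a further agent that is not named here; a lower number here means a stronger inhibitor, a higher number a weaker inhibitor
compound 2, `Cc1c(OCC(=O)Nc2cccc(NC(=O)c3ccc(N(C)C)cc3)c2)ccc2c(=O)ccoc12`, 4160 nM in this assay
compound 3, `CCc1ccc(C(=O)Nc2cccc(NC(=O)COc3ccc4c(=O)ccoc4c3)c2)cc1`, 24 nM in this assay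

Compound 3 gives the lowest number of the three in this assay; its gap to compound 1 and its gap to compound 2 both lie beyond the scatter, so compound 3 is the strongest inhibitor of the measured set. Compound 1 and compound 2 differ from compound 3 in more than one place, so no single step between measured compounds is available and no cause can be attached to the gaps.

The next compound, compound 4, `Cc1cc(C(=O)Nc2cccc(NC(=O)COc3ccc4c(=O)ccoc4c3)c2)no1`, differs from compound 3 in one place:

5-methyl-1,2-oxazol-3-yl in place of 4-ethylphenyl on a carbonyl carbon

Among the measured compounds shown here, no measured step for this change is available. The expectation for the step in this assay is a move to a weaker inhibitor, of a size beyond the scatter, estimated as a 6.3-fold higher number from compound 3 to compound 4 (0.80 log units; beyond the scatter). On that basis compound 4 is expected to give about 150 nM in this assay, with a range from 30 nM to 800 nM; the measurement will decide.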

Compound 4, half-maximal inhibitory concentration: 5 nM
Compound 4: the middle estimate sits 30-fold (1.48 log units) above what was measured; measured number below the stated range.
By their numbers in this assay, from the lowest: compound 4; then compound 3; then compounds 1 and 2 (each within the scatter of the next).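

On a carbonyl carbon whose other neighbour is an amide-type nitrogen, the aromatic group can be exchanged with a gain rather than a loss in this assay: 5-methyl-1,2-oxazol-3-yl in place of 4-ethylphenyl gives a modest step beyond the scatter (a 4.8-fold lower number from compound 3 to compound 4 (0.68 log units; beyond the scatter)). Among the compounds shown here, the earlier compounds differ from one another in more than one place, so this is the first reading of a single change, and it shows that a six-membered aromatic ring of carbon only is not required at this position, at least on the core shared by compound 3 and compound 4. No measurement available here bears on the reason for the step.

The change alters ring size, hetero atom content, hydrogen-bond acceptor count and the alkyl group at once, so this one step cannot assign the gain to any of them. Open questions are how a plain phenyl, an unsubstituted 1,2-oxazol-3-yl or a 1,2-oxazol-3-yl carrying ethyl in place of methyl would read at this position, and whether the gain holds on other cores.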